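Fluoro in place of methyl: working notes on the series

The source may hold more compounds than are shown below. What is called first, only, known or untested is meant among the compounds shown, and "the series" means these compounds.

Compound 1 `CCc1ccc(-c2nc3c(c(C)nn3-c3ccccc3)c(-c3ccccc3I)c2C#N)cc1`: > 20000 nM (a limit of the assay)
Compound 2 `Cc1ccc(-c2nc3c(c(C)nn3-c3ccccc3)c(-c3ccccc3O)c2C#N)cc1`: 22200 nM

Both entries come from an ADME assay on BJ cells (Homo sapiens) for cytotoxicity, with a stated time of 72 h; on this read-out lower numbers stand for an effect already at smaller amounts and higher numbers for an effect only at larger amounts of compound. Going by the values given here, compound 2 holds the only actual number. The entry for compound 1 is a limit and not a number. Compound 3 `Cc1nn(-c2ccccc2)c2nc(-c3ccc(F)cc3)c(C#N)c(-c3ccccc3O)c12` has fluoro in place of methyl on an aromatic carbon, para to a large group, so 4-methylphenyl becomes 4-fluorophenyl (fluoro in place of methyl on an aromatic carbon). Among the compounds with values here, no measured step covers this change, and the expectation rests on compound 2 at 22200 nM. No step beyond the scatter is expected in this assay. The estimated value for compound 3 is 22000 nM, with an expected range of 10000 nM to 45000 nM.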

Compound 3, half-maximal effective concentration: > 20000 nM
Compound 3: a limit, no number (the forecaster's own chance of this, stated with the estimate: 40%); the middle value is on the limit's open side.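

Going by these compounds alone, compound 3 gives > 20000 nM, a limit and not a number, so no step from compound 2 to compound 3 can be read. The compounds shown leave open what size of step, if any, goes with 4-methylphenyl to 4-fluorophenyl.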